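Swapping One Group on a Weakly Active Series

The source may report more compounds than this note shows. Statements on the series, on what has been measured and on what is new or still open speak of the compounds shown alone.

- Compound 1 `CC(=O)c1ccc(NC(=O)Cn2nc(-c3ccc(Cl)cc3)nc2N)cc1`: 20.3%
- Compound 2 `C/C(=N/O)c1ccc(NC(=O)Cn2nc(C(F)(F)F)nc2N)cc1`: 20.3%
- Compound 3 `C/C(=N/O)c1ccc(NC(=O)Cn2nc(-c3ccccc3)nc2N)cc1`: 15.8%

In a functional assay on PC-3 cells (Homo sapiens) for inhibition, read by sulforhodamine B assay, with a stated time of 48 h, tested at 10 uM (a higher number here means more inhibition of growth at the concentration tested, a lower number less inhibition of growth), compound 2 gives 20.3%, and compound 1 gives the same number at 20.3%. The nearest other value among these compounds is therefore identical, and the third is also close.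

Compound 4 `CC(=O)c1ccc(NC(=O)Cn2nc(C(F)(F)F)nc2N)cc1` has not yet been measured. It differs from compound 2 at one place: a group of 3 heavy atoms (2 carbon, 1 oxygen; no ring) in place of a group of 4 heavy atoms (2 carbon, 1 nitrogen, 1 oxygen; no ring), on an aromatic carbon. The incoming group is an acetyl, and the change sits on an aromatic carbon of a six-membered aromatic ring of carbon only, para to a large group.

Among the compounds with values here, no measured step changes this group alone. Within the data shown here, the only single-place step is a number 4.5 percentage points lower from compound 2 to compound 3 (within the scatter), with phenyl in place of trifluoromethyl on an aromatic carbon, so it concerns a different place on the molecule. Compound 1 carries the acetyl, yet it also differs elsewhere from compound 3, so the two values cannot isolate the swap: compound 3 gives 15.8%, and compound 1 gives 20.3%.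

With so little evidence, no step beyond the scatter is expected in this assay. The estimated change is a number 0.3 percentage points lower from compound 2 to compound 4 (within the scatter). For compound 4 the expected value is 20%, with an estimated range of 8% to 33%.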

Compound 4, percent growth inhibition at one concentration: 10.6%
Compound 4: middle estimate off by 9.4 percentage points, on the high side; low and high end bracket the measured number.
By their numbers in this assay, from the lowest: compounds 4, 3, 1 and 2 (each within the scatter of the next).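

In this assay, within the data shown here, acetyl in place of the group of 4 heavy atoms (2 carbon, 1 nitrogen, 1 oxygen), on an aromatic carbon para to a large group, gives a number 9.7 percentage points lower from compound 2 to compound 4 (within the scatter) and is the first step that reads this position alone; this swap removes the 1 hydrogen-bond donor counted on the leaving group, yet the step stays within the scatter. With the acetyl held constant, trifluoromethyl in place of 4-chlorophenyl gives a number 9.7 percentage points lower from compound 1 to compound 4 (within the scatter) and adds a second single-place step at the other varied position, which is also within the scatter. Neither change therefore separates its pair of compounds in this read-out, and no measurement shown bears on why the numbers fall as they do.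

From the compounds shown here alone, whether a different group at the same aromatic carbon, such as an amine or a carboxylic acid, would give a step beyond the scatter remains open. Also open, going by these compounds, is how these compounds would compare across a range of concentrations, since each number here comes from a single tested concentration.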